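The compounds below may be only part of what the source reports. "The series", "measured", "known", "first", "only" and "open" are said of these compounds alone.

Compound 1 `CC1(C)[C@@H]2CC[C@@]1(CS(=O)(=O)N1CCN(c3ncccc3C(F)(F)F)CC1)C(=O)C2` is the starting point of this comparison. In a functional assay on CHO-K1 cells for antagonist activity at C-X-C chemokine receptor type 3 (Homo sapiens), read by FLIPR and calcium flux (a higher number here means a weaker inhibitor, a lower number a stronger inhibitor), compound 1 gives only a limit, > 31600 nM, and not a measured number. Two related compounds do give numbers in this assay: compound 2 `CC1(C)[C@@H]2CC[C@@]1(CS(=O)(=O)N1CCN(c3ncc(C(F)(F)F)cc3[N+](=O)[O-])CC1)C(=O)C2` gives 3160 nM, and compound 3 `CC1(C)[C@@H]2CC[C@@]1(CS(=O)(=O)N1CCCN(c3ccc(C(F)(F)F)cn3)CC1)C(=O)C2` gives 6310 nM. Compound 1 therefore stands at the weak end of what has been measured so far, as recorded by the limit of > 31600 nM in this assay, at which 1 of the 3 values shown sits.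

Compound 4 `CC1(C)[C@@H]2CC[C@@]1(CS(=O)(=O)N1CCN(c3ccc(C(F)(F)F)cc3)CC1)C(=O)C2` has not yet been measured in this assay. It differs from compound 1 in one place: 4-(trifluoromethyl)phenyl in place of 3-(trifluoromethyl)pyridin-2-yl on an amine nitrogen in a ring. For the measured compounds named here, no pair of measured compounds shares this exact change, so there is no direct step to lean on. Compound 2 and compound 3 both remain weak in this assay, and a large gain from a single ring change would be unexpected. The step from compound 1 to compound 4 is expected to be modest, an at least 2.6-fold lower number from compound 1 to compound 4 (0.42 log units; beyond the scatter), in the direction of a somewhat stronger inhibitor. Compound 4 is estimated at 12000 nM in this assay, with a likely range from 3000 nM to 40000 nM.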

Compound 4, half-maximal inhibitory concentration: > 31600 nM
Compound 4 was reported as a limit; the forecaster's own chance of this, stated with the estimate: 40%; middle value at least 2.6-fold (0.42 log units) away from the limit.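

For the compounds shown here, compound 4 gives a limit, as compound 1 does, so no step between compound 1 and compound 4 can be read: the limit of > 31600 nM in this assay, at which 2 of the 4 values shown sit.

Still open, going by these compounds, is whether 4-(trifluoromethyl)phenyl or 3-(trifluoromethyl)pyridin-2-yl gives the stronger inhibitor on the shared core.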